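A few compounds are considered here, and "the series" means these few. Any claim that something is new, unique, unknown or untested is made for them only; others in the source may bear on it.

Of the compounds shown here, three built on one shared core have been tested in an ADME assay on L02 cells (Homo sapiens) for cytotoxicity, read by MTT assay, with a stated time of 48 h; a higher number here means a weaker inhibitor, a lower number a stronger inhibitor. Compound 1, `CN(CCC#N)C[C@H]1CN(c2ccc(-n3cc(-c4ccccn4)cn3)c(F)c2)C(=O)O1`, reaches only a limit of the assay in this assay, > 400 ug/mL. Compound 2, `COC[C@H]1CN(c2ccc(-n3cc(-c4ccccn4)cn3)c(F)c2)C(=O)O1`, likewise gives only a limit, > 400 ug/mL. Within the data shown here, compound 3, `O=C1O[C@@H](Cn2ccnn2)CN1c1ccc(-n2cc(-c3ccccn3)cn2)c(F)c1`, is the one compound with a real number in this assay, 49 ug/mL. Among the measured compounds shown here, compounds 1 and 2 sit at the limit of the assay (the limit of > 400 ug/mL in this assay, at which 2 of the 3 values shown sit), so compound 3 stands as the only number among the three values. The step from an at least 8.1-fold lower number from compound 1 to compound 3 (0.91 log units; beyond the scatter) and the step from an at least 8.1-fold lower number from compound 2 to compound 3 (0.91 log units; beyond the scatter) both point the same way: exchanging the group on the saturated chain carbon for the triazole brought the number down, beyond the scatter.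

Compound 4, `CCC(=O)NC[C@H]1CN(c2ccc(-n3cc(-c4ccccn4)cn3)c(F)c2)C(=O)O1`, has not yet been measured in this assay. It differs from compound 3 by propanoylamino in place of 1H-1,2,3-triazol-1-yl on a saturated chain carbon bound to a saturated ring carbon. The two measured steps at this place were both at least modest, and both had the triazole on the low side; the exchange in compound 4 moves away from the triazole, so a rise in the number is expected, quite possibly back to the limit. The estimate for compound 4 in this assay is 250 ug/mL, with a range from 80 ug/mL to 400 ug/mL. This estimate corresponds to an expected step of a 5.1-fold higher number from compound 3 to compound 4 (0.71 log units; beyond the scatter).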

Compound 4, half-maximal inhibitory concentration: 204 ug/mL
Compound 4: the middle estimate sits 1.2-fold (0.09 log units) above what was measured, within the range that was stated.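

In this assay, the exchange gives a 4.2-fold higher number from compound 3 to compound 4 (0.62 log units; beyond the scatter), so the low number of compound 3 does not carry over to every group of that size on a saturated chain carbon bound to a saturated ring carbon: propanoylamino and 1H-1,2,3-triazol-1-yl each have 5 heavy atoms. Unlike compounds 1 and 2, compound 4 also gives a real number for a group with no ring, which leaves 1H-1,2,3-triazol-1-yl, with its five-membered aromatic ring, as the group with the lowest number among those shown. Against the other two groups the result reads an at least 1.9-fold lower number from compound 2 to compound 4 (0.29 log units; that floor lies within the scatter) and an at least 1.9-fold lower number from compound 1 to compound 4 (0.29 log units; that floor lies within the scatter), and these steps give only floors because the far end of each is a limit: the limit of > 400 ug/mL in this assay, at which 2 of the 4 values shown sit.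

Going by these compounds, it remains open whether the low number goes with a five-membered aromatic ring at this place in general or with 1H-1,2,3-triazol-1-yl alone, a question that a 1H-pyrazol-1-yl or 1H-tetrazol-1-yl group on the same carbon could address. An acetylamino group or a primary amine there could show how far the number depends on the propanoyl chain.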